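A few compounds are considered here, and "the series" means these few. Any claim that something is new, unique, unknown or untested is made for them only; others in the source may bear on it.

Measured compounds so far:

compound 1 — `COc1cc(/C=N/NC(=O)CCN2CCN(c3ccnc4cc(Cl)ccc34)CC2)ccc1OC(C)C`
compound 2 — `CN(C)c1ccc(/C=N/NC(=O)CCN2CCN(c3ccnc4cc(Cl)ccc34)CC2)cc1`

In an ADME assay on cells (Splenocyte, Mus musculus, strain BALB/c) for cytotoxicity, read by thymidine incorporation, with a stated time of 24 h (a higher number here means a weaker inhibitor, a lower number a stronger inhibitor), compound 1 gives 8800 nM. Compound 2 does not give a number in this assay but only a limit, > 100000 nM. That limit is where compound 2 stands, as shown by the limit of > 100000 nM in this assay, at which 1 of the 2 values shown sits, so its true value is known only as a bound. Among the measured compounds shown here, the single measured step, an at least 11-fold higher number from compound 1 to compound 2 (1.05 log units; beyond the scatter), is therefore itself a bound, and it is the only step that bears on what follows.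

Compound 3, `COc1cc(/C=N/NC(=O)CCN2CCN(c3ccnc4cc(Cl)ccc34)CC2)ccc1OC(C)=O`, has not yet been measured in this assay. It differs from compound 2 by 4-acetoxy-3-methoxyphenyl in place of 4-(dimethylamino)phenyl on a carbon with a double bond to nitrogen. The group that leaves is the one that entered in the measured step, and the group that enters shares its 3-methoxyphenyl pattern with the group of compound 1. The measured step is thus expected to run partly in reverse, with compound 3 expected to come back toward compound 1, an at least 6.6-fold lower number from compound 2 to compound 3 (0.82 log units; beyond the scatter), though the limit on compound 2 leaves the size uncertain. For compound 3 the estimate is 15000 nM, with a range from 5000 nM to 60000 nM.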

Compound 3, half-maximal inhibitory concentration: 15800 nM
Compound 3: middle estimate off by 1.1-fold (0.02 log units), on the low side; the range from low to high includes it.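

In this assay, the change at the carbon with a double bond to nitrogen gives an at least 6.3-fold lower number from compound 2 to compound 3 (0.80 log units; beyond the scatter), and the size of this step is only a bound, as compound 2 has a limit and not a number: the limit of > 100000 nM in this assay, at which 1 of the 3 values shown sits. With the methoxy group kept and only the group on the oxygen changed, acetyl in place of isopropyl gives a 1.8-fold higher number from compound 1 to compound 3 (0.25 log units; within the scatter), so compound 1 and compound 3 cannot be told apart in this assay. Among these three compounds, then, the two groups on that oxygen read alike, whereas the earlier pair showed only that replacing the whole 4-isopropoxy-3-methoxyphenyl group with 4-(dimethylamino)phenyl moved the number beyond the scatter.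

The compounds shown leave open whether the methoxy group, the oxygen-linked group or the dimethylamino group itself accounts for the distance between compound 2 and the other two, as these parts all change together in each step to compound 2. They also leave open how a benzyl group or a longer alkyl chain on that oxygen would read, and whether an amine carried there would behave like the dimethylamino group of compound 2.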